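Meta-substituent swap on the benzyloxy ring: methyl to nitro

This account rests on a few compounds, and the source may have more. Where it says the series, first, only, none or still open, it means among the compounds named here.

Measured compounds:
Compound 1, `COc1cccc(OC)c1OCCNCCOc1ccccc1OCc1cccc(Cl)c1`: 0.159 nM
Compound 2, `COc1cccc(OC)c1OCCNCCOc1ccccc1OCc1cccc(C)c1`: 0.251 nM

Of the compounds shown here, two sharing the same core have been measured in an assay on CHO cells for displacement of a labelled ligand from Alpha-1B adrenergic receptor (Homo sapiens); a higher number here means a weaker inhibitor, a lower number a stronger inhibitor. Compound 1 carries a chloro group on the benzyloxy ring and gives 0.159 nM in this assay. The methyl analogue is compound 2, which gives 0.251 nM. Going by the values given here, the only step between them, a 1.6-fold higher number from compound 1 to compound 2 (0.20 log units; within the scatter), is within the scatter, so compound 2 cannot be separated from compound 1 on these numbers; the two sit together at the sub-nanomolar end.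

Compound 3, `COc1cccc(OC)c1OCCNCCOc1ccccc1OCc1cccc([N+](=O)[O-])c1`, is not yet measured. It differs from compound 2 by nitro in place of methyl on an aromatic carbon. Among the compounds with values here, no measured step involves a nitro group, and the one step on record, a 1.6-fold higher number from compound 1 to compound 2 (0.20 log units; within the scatter), shows that the chloro-to-methyl exchange at this position left the number within the scatter. On these data alone, whether a nitro group at the same position behaves like those two small groups is unknown; the change is larger in what it brings in, so a modest loss is allowed for but none beyond the scatter is expected as the central case. Compound 3 is therefore estimated at 0.4 nM, between 0.12 nM and 1.3 nM, an expected step of a 1.6-fold higher number from compound 2 to compound 3 (0.20 log units; within the scatter).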

Compound 3, inhibition constant: 0.794 nM
Estimate against measurement, compound 3: 2.0-fold (0.30 log units) below; low and high end bracket the measured number.
By their numbers in this assay, from the lowest: compounds 1 and 2 (each within the scatter of the next); then compound 3.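

Nitro in place of methyl gives a 3.2-fold higher number from compound 2 to compound 3 (0.50 log units; beyond the scatter) and nitro in place of chloro gives a 5.0-fold higher number from compound 1 to compound 3 (0.70 log units; beyond the scatter) in this assay so this position is not indifferent to the group it carries, something the pair of compound 1 and compound 2 could not show. Compound 3 is the weakest of the three, yet both steps are modest, and a sub-nanomolar number survives the exchange of methyl for a group with more heavy atoms and with hydrogen-bond acceptors that methyl lacks. Nothing measured here bears on why nitro separates from the other two groups.

The three compounds leave open whether an amine or a carboxylic acid at this position would stay with chloro and methyl or fall with nitro, or go further still. They also leave open whether nitro would give a similar step elsewhere on the ring, since the whole comparison rests on a single nitro compound and on one position of the shared core.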